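Imidazole to Imidazolone: What Compound 3 Might Show

The source may hold more compounds than are shown below. What is called first, only, known or untested is meant among the compounds shown, and "the series" means these compounds.

Compound 1 `Fc1ccc2c(c1)c(OCCn1ccnc1)nn2-c1ccccc1F` was tested in an ADME assay on the whole organism (strain Sprague-Dawley) for metabolic stability, with Rattus norvegicus as the target, read by LC-MS (a lower number here means that the compound disappears faster, a higher number that the compound lasts longer), and gave 1.1 h there. Compound 2 `O=C1NCCN1CCOc1nn(-c2ccc(F)cc2F)c2ccc(F)cc12` gave 0.94 h in this assay. Compound 1 carries the larger of the two numbers, yet the gap to compound 2 lies within the usual scatter, so the two stand level. Compound 3 `O=c1[nH]ccn1CCOc1nn(-c2ccccc2F)c2ccc(F)cc12` differs from compound 1 by a group of 6 heavy atoms (3 carbon, 2 nitrogen, 1 oxygen; one five-membered aromatic ring with 2 hetero atoms) in place of a group of 5 heavy atoms (3 carbon, 2 nitrogen; one five-membered aromatic ring with 2 hetero atoms), on a saturated chain carbon, two bonds along the chain from an oxygen on an aromatic ring. Among the compounds with values here, no measured pair shows what such a change does in this assay. The step of no change at the digits printed from compound 1 to compound 3 (within the scatter) is therefore expected to stay within the scatter. Compound 3 is expected to give 1.1 h, in a range from 0.5 h to 2.5 h.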

Compound 3, half-life: 0.4 h
Estimate against measurement, compound 3: 2.8-fold (0.44 log units) above; measured number below the stated range.
By their numbers in this assay, from the lowest: compound 3; then compounds 2 and 1 (each within the scatter of the next).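

At this place, on a saturated chain carbon, two bonds along the chain from an oxygen on an aromatic ring, the group matters in this assay: putting the ring with a carbonyl and a hydrogen-bond donor in place of 1H-imidazol-1-yl gives a 2.8-fold lower number from compound 1 to compound 3 (0.44 log units; beyond the scatter). This is the only step shown, and it lies beyond the scatter. No measurement at hand bears on why the number falls. On these data alone, whether the carbonyl or the amide hydrogen carries this step stays open, as does how an amine, a carboxylic acid or a longer chain would fare here.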